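A Carboxy Side Chain on the Amide Nitrogen

A few compounds are considered here, and "the series" means these few. Any claim that something is new, unique, unknown or untested is made for them only; others in the source may bear on it.

Measured in a functional assay on PC-3 cells (Homo sapiens) for antiproliferative activity, read by MTT assay, with a stated time of 24 h; a lower number here means a stronger inhibitor, a higher number a weaker inhibitor:
- compound 1 `CCn1c(C(=O)NCCN)ccc1C(CC)(CC)c1ccc(OCS(=O)(=O)c2ccccc2)c(C)c1` gives 6890 nM
- compound 2 `CCn1c(C(=O)N[C@@H](C)CO)ccc1C(CC)(CC)c1ccc(OCS(=O)(=O)c2ccccc2)c(C)c1` gives 9520 nM
- compound 3 `CCn1c(C(=O)N[C@@H](CO)CCO)ccc1C(CC)(CC)c1ccc(OCS(=O)(=O)c2ccccc2)c(C)c1` gives 14100 nM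

All three share one core and differ only in the group on the amide-type nitrogen. Compound 3, at 14100 nM, is not separated from every neighbour. The data show a 1.5-fold higher number from compound 2 to compound 3 (0.17 log units; within the scatter), and also a 2.0-fold higher number from compound 1 to compound 3 (0.31 log units; beyond the scatter). The remaining measured step is a 1.4-fold higher number from compound 1 to compound 2 (0.14 log units; within the scatter).

Compound 4 `CCn1c(C(=O)N[C@H](C(=O)O)C(C)C)ccc1C(CC)(CC)c1ccc(OCS(=O)(=O)c2ccccc2)c(C)c1` has not yet been measured. It changes the same position: 1-carboxy-2-methylpropyl in place of 3-hydroxy-1-(hydroxymethyl)propyl on an amide-type nitrogen. Among the compounds with values here, no measured compound carries this group, so the three steps bear on it only as swaps at the same place. Each of them is small, so a large shift in this assay is not expected, and they give no firm direction for the new group. For compound 4 the expected change is a 1.2-fold lower number from compound 3 to compound 4 (0.07 log units; within the scatter), which means no real movement is anticipated. Compound 4 is estimated at 12000 nM, within an expected range of 5000 nM to 30000 nM.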

Compound 4, half-maximal inhibitory concentration: 3650 nM
For compound 4 the middle estimate is 3.3-fold (0.52 log units) above the measured one; measured number outside the range, below it.
By their numbers in this assay, from the lowest: compounds 4, 1, 2 and 3 (each within the scatter of the next, the first and the last beyond it).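

In this assay, the group on the amide-type nitrogen can take the number down beyond the scatter: 1-carboxy-2-methylpropyl gives a 3.9-fold lower number from compound 3 to compound 4 (0.59 log units; beyond the scatter) when it replaces 3-hydroxy-1-(hydroxymethyl)propyl, and a 2.6-fold lower number from compound 2 to compound 4 (0.42 log units; beyond the scatter) when it replaces 1-(hydroxymethyl)ethyl. Set against 2-aminoethyl, the same group gives a 1.9-fold lower number from compound 1 to compound 4 (0.28 log units; within the scatter) and so cannot be told apart from it, which means the result separates the carboxy side chain from the two hydroxy side chains only. Nothing measured here gives a reason for this result.

The compounds shown leave open whether the carboxylic acid or the branched carbon chain of the new group accounts for the step, which a plain 2-methylpropyl group or a carboxymethyl group would separate. Going by these compounds, what the opposite stereocentre on the same group would give also remains open.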